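From acid to chlorophenyl amide in a growth assay

This account rests on a few compounds, and the source may have more. Where it says the series, first, only, none or still open, it means among the compounds named here.

Measured so far in a functional assay on Bel-7402 cells (Homo sapiens) for inhibition, read by MTT assay, with a stated time of 24 h, tested at 1 ug/mL (on this read-out higher numbers stand for more inhibition of growth at the one concentration tested and lower numbers for less inhibition of growth), are:
compound 1 (`CC(=O)SCCC(CCCCC(=O)O)SC(C)=O`) with 12.8%
compound 2 (`O=C(CCCCC(S)CCS)Nc1ccc([N+](=O)[O-])c(C(F)(F)F)c1`) with 0.68%
compound 3 (`COc1ccc(NC(=O)CCCCC(S)CCS)cc1`) with 3.96%

Compound 1 holds the highest of the three numbers, beyond the scatter from compound 2 but within it from compound 3. Compound 4 (`CC(=O)SCCC(CCCCC(=O)Nc1ccc(Cl)cc1)SC(C)=O`) has (4-chlorophenyl)amino in place of hydroxy on a carbonyl carbon of compound 1 ((4-chlorophenyl)amino in place of hydroxy on a carbonyl carbon) and is still unmeasured. Compound 3 also has an amide there and gives 3.96% but differs from compound 4 elsewhere as well, so it guides only loosely. Among the compounds with values here, no measured pair isolates this change, so a small fall, none beyond the scatter, is expected. The expected step in this assay is a number 4.8 percentage points lower from compound 1 to compound 4 (within the scatter) and stays within the scatter. Compound 4 is estimated at 8% with 0% to 20% as its expected range.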

Compound 4, percent growth inhibition at one concentration: 3.07%
Compound 4: middle estimate off by 4.9 percentage points, on the high side; measured number inside the range.
By their numbers in this assay, from the lowest: compounds 2, 4, 3 and 1 (each within the scatter of the next, the first and the last beyond it).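

In this assay, within the data shown here, the pair gives the first direct reading of this position, where (4-chlorophenyl)amino takes the place of hydroxy on a carbonyl carbon, and it shows a number 9.7 percentage points lower from compound 1 to compound 4 (within the scatter). The carboxylic acid of compound 1 is therefore not shown to be needed for this read-out, though the small step cannot settle the matter. Nothing measured here explains the result. Still open, on these data alone, is whether a methyl ester or a benzylamino group on that carbonyl carbon would give a number beyond the scatter from compound 1.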